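A few compounds are considered here, and "the series" means these few. Any claim that something is new, unique, unknown or untested is made for them only; others in the source may bear on it.

Working notes on the series. In an ADME assay on HEK293 cells (Homo sapiens) for cytotoxicity, read by MTT assay, with a stated time of 48 h (on this read-out higher numbers stand for weaker inhibition and lower numbers for stronger inhibition), compound 1 `Cc1cc(NC(=O)c2cc(C(F)(F)F)cc(C(F)(F)F)c2)ccc1NS(C)(=O)=O` gives 163000 nM. Compound 2 `CS(=O)(=O)Nc1ccc(NC(=O)c2cccc(C(F)(F)F)c2)cc1Cl` returns only a limit in this assay, > 250000 nM, so no number is known for it. On the values shown, compound 2 stands at the limit of > 250000 nM in this assay, at which 1 of the 2 values shown sits. Compound 3 `CS(=O)(=O)Nc1ccc(NC(=O)c2cc(C(F)(F)F)cc(C(F)(F)F)c2)cc1Cl` is not yet measured in this assay. The change from compound 2 to compound 3 is trifluoromethyl in place of hydrogen on an aromatic carbon. No step between measured compounds is shown, so the size of this change in this assay cannot be taken from the data; the expectation is a step no larger than the usual scatter, with no set direction, and a reading at the limit remains almost as likely as a number. Compound 3 is therefore expected to give 200000 nM, with a range of 100000 nM to 400000 nM. The expected step is an at least 1.2-fold lower number from compound 2 to compound 3 (0.09 log units; that floor lies within the scatter).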

Compound 3, half-maximal inhibitory concentration: 185000 nM
Estimate against measurement, compound 3: 1.1-fold (0.03 log units) above; the measured number falls inside the stated range.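

In this assay, trifluoromethyl placed meta to a trifluoromethyl group turns a reading at the limit into a number, giving an at least 1.3-fold lower number from compound 2 to compound 3 (0.13 log units; that floor lies within the scatter). Compound 2 remains a limit and not a number, so this step has a floor but no known size: the limit of > 250000 nM in this assay, at which 1 of the 3 values shown sits. At the other changed place, chloro in place of methyl on an aromatic carbon gives a 1.1-fold higher number from compound 1 to compound 3 (0.05 log units; within the scatter), so compound 1 and compound 3 cannot be told apart in this assay.

On these data alone, whether the full step from hydrogen to trifluoromethyl lies beyond the scatter remains open. Also open, as far as these compounds go, is how an amine, a carboxylic acid or a methoxy group at either of these places would read in this assay.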